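This account rests on a few compounds, and the source may have more. Where it says the series, first, only, none or still open, it means among the compounds named here.

Working notes on the series, read in a functional assay on MCF7 cells (Homo sapiens) for antiproliferative activity, read by MTT assay, with a stated time of 48 h; a higher number here means a weaker inhibitor, a lower number a stronger inhibitor. Compound 1 `Brc1ccc2[nH]c(-c3cn(-c4ccccc4)nc3-c3ccccc3)nc2c1` gives 830 nM and compound 2 `Fc1ccc(-c2nn(-c3ccccc3)cc2-c2nc3cc(F)ccc3[nH]2)cc1` gives 950 nM, two values within the scatter of each other. Compound 3 `Fc1ccc(-c2nn(-c3ccccc3)cc2-c2nc3cc(Cl)ccc3[nH]2)cc1` gives 2230 nM, the highest of the three numbers, and both other compounds lie beyond the scatter from it.

The next structure is compound 4 `Fc1ccc(-c2nn(-c3ccccc3)cc2-c2nc3cc(Br)ccc3[nH]2)cc1`, with bromo in place of chloro on an aromatic carbon.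

For the measured compounds named here, the one measured step that bears on this is a 2.3-fold higher number from compound 2 to compound 3 (0.37 log units; beyond the scatter), with chloro in place of fluoro on an aromatic carbon. It is modest, and a single step sets no trend. Compound 2 and compound 3 carry a fluoro group that is absent from compound 1, whose bromo stands with 830 nM. That value is only indirect support for a bromo compound lying under the number of compound 3, since the two compounds differ in more than one place.

A small move toward a lower number is therefore expected, probably none beyond the scatter. The expected change is a 1.2-fold lower number from compound 3 to compound 4 (0.09 log units; within the scatter). For compound 4 the estimate in this assay is 1800 nM, with an expected range of 800 nM to 3800 nM.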

Compound 4, half-maximal inhibitory concentration: 3210 nM
Estimate against measurement, compound 4: 1.8-fold (0.25 log units) below; the measured number falls inside the stated range.
By their numbers in this assay, from the lowest: compounds 1 and 2 (each within the scatter of the next); then compounds 3 and 4 (each within the scatter of the next).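

In this assay, the change at this position gives a 1.4-fold higher number from compound 3 to compound 4 (0.16 log units; within the scatter), so bromo and chloro on this aromatic carbon cannot be told apart, and the earlier rise on going from fluoro to chloro does not carry on as a further rise to bromo. Fluoro stays separate from the larger halogen in this comparison, with a 3.4-fold higher number from compound 2 to compound 4 (0.53 log units; beyond the scatter), a modest step that points the same way as the one from fluoro to chloro, though two steps from one parent compound make only a narrow pattern. The comparison with compound 1 adds a second site to the series: with bromo held fixed, fluoro in place of hydrogen on an aromatic carbon gives a 3.9-fold higher number from compound 1 to compound 4 (0.59 log units; beyond the scatter), so the number responds to a change away from the halogen position too, and also modestly. Nothing shown gives a reason for any of these steps.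

The compounds shown leave open how an amine, a methoxy group or a carboxylic acid would read at the halogen position, since only three halogens appear there. They also leave open whether fluoro in place of hydrogen gives a similar step when chloro or fluoro stands at the halogen position, as that step is read with bromo alone.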